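Positional isomers of a pyrimidinyl-methoxy aryl series at the receptor

This account rests on a few compounds, and the source may have more. Where it says the series, first, only, none or still open, it means among the compounds named here.

Compound 1 `CC(=O)Nc1ccccc1OCc1cc(C)nc(-c2ccccn2)n1` carries an acetamido on the aryl ring; compound 2 `CC(=O)Nc1cccc(OCc2cc(C)nc(-c3ccccn3)n2)c1` has the same atoms joined differently, and the difference between the two cores is not broken down here. In a functional assay on cells for antagonist activity at Free fatty acid receptor 1 (Homo sapiens), read by TR-FRET and inositol phosphate accumulation, with a stated time of 2 h (on this read-out lower numbers stand for stronger inhibition and higher numbers for weaker inhibition), compound 1 gives a limit, > 39800 nM. Compound 2 likewise gives only a limit, > 39800 nM. Compound 3 `Cc1cc(COc2ccccc2S(C)(=O)=O)nc(-c2ccccn2)n1` differs from compound 1 by methylsulfonyl in place of acetamido on an aromatic carbon, and compound 3 also gives only a limit in this assay, > 39800 nM; the step that the two limits leave unreadable from compound 1 to compound 3 is therefore unreadable, since (the limit of > 39800 nM in this assay, at which 3 of the 3 values shown sit). Compound 4 `Cc1cc(COc2cccc(S(C)(=O)=O)c2)nc(-c2ccccn2)n1` differs from compound 2 by methylsulfonyl in place of acetamido on an aromatic carbon, the same kind of change, the place being meta rather than ortho to a large group. Because (the limit of > 39800 nM in this assay, at which 3 of the 3 values shown sit), compound 4 is expected to remain at the limit, an estimated 50000 nM, a step that the limit leaves unreadable from compound 2 to compound 4.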

Compound 4, half-maximal inhibitory concentration: > 39800 nM
Compound 4 was reported as a limit; the forecaster's own chance of this, stated with the estimate: 85%; the middle value is on the limit's open side.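

The step between compound 2 and compound 4 cannot be read, since both values are limits: the limit of > 39800 nM in this assay, at which 4 of the 4 values shown sit.

The compounds shown leave open how much methylsulfonyl in place of acetamido changes inhibition, and whether any compound in this series gives a measurable value.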